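Bromo for Trifluoromethyl on the Amide Aryl Ring

A few compounds are considered here, and "the series" means these few. Any claim that something is new, unique, unknown or untested is made for them only; others in the source may bear on it.

In an assay on cells for inhibition of sodium- and chloride-dependent glycine transporter 1 (Homo sapiens) (a higher number here means that more compound is needed for the effect, a lower number that less compound is needed), compound 1 `COc1cc(C(F)(F)F)cc(C(F)(F)F)c1C(=O)NC1(c2ccccc2)CCCN(C(C)=O)C1` gives only a limit of the assay, > 10000 nM. Compound 2 `COc1cc(C(F)(F)F)cc(C(F)(F)F)c1C(=O)NC1(c2ccccc2)CCCN(C(=O)c2ccccc2)C1` likewise gives only a limit, > 10000 nM. The step that the two limits leave unreadable from compound 1 to compound 2 therefore has no readable size. Among the measured compounds shown here, compound 3 `CN1CCCC(NC(=O)c2ccc(C(F)(F)F)cc2C(F)(F)F)(c2ccccc2)C1` gives the only number in this assay, 540 nM, while the two other values sit at the limit of > 10000 nM in this assay, at which 2 of the 3 values shown sit. Compound 4 `CN1CCCC(NC(=O)c2ccc(C(F)(F)F)cc2Br)(c2ccccc2)C1` differs from compound 3 by bromo in place of trifluoromethyl on an aromatic carbon. No measured step bears on this change: the single step shown is unreadable, and the pair of compound 3 and compound 4 has no precedent here. The step is expected to stay within the scatter, with a 1.1-fold higher number from compound 3 to compound 4 (0.05 log units; within the scatter) as the estimate. Compound 4 is accordingly expected to give 600 nM in this assay, estimated between 200 nM and 2000 nM.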

Compound 4, half-maximal effective concentration: 300 nM
Compound 4: the middle estimate sits 2.0-fold (0.30 log units) above what was measured, within the range that was stated.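

In this assay, bromo in place of trifluoromethyl on this aromatic carbon, ortho to a large group, gives a 1.8-fold lower number from compound 3 to compound 4 (0.26 log units; within the scatter) and is the only readable step among the compounds shown. At this position, one bromine atom thus stands in for the four heavy atoms of trifluoromethyl, with the two values staying within the scatter of each other. Nothing measured here gives a cause for this result. Still open, from the compounds shown here alone, is whether an amine or a carboxylic acid on this aromatic carbon would also stay within the scatter of compound 3.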